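The source may hold more compounds than are shown below. What is called first, only, known or untested is meant among the compounds shown, and "the series" means these compounds.

Compound 3 `COC(=O)c1sc2cc(C#Cc3ccc(F)cc3)cnc2c1N` stands highest of the two numbers in a functional assay on NCI-H460 cells (Homo sapiens) for inhibition, read by sulforhodamine B assay, with a stated time of 48 h (a higher number here means a weaker inhibitor of growth, a lower number a stronger inhibitor of growth), where compound 3 gives 24000 nM. Compound 1 `COC(=O)c1sc2cc(C#Cc3ccc(OC)cc3)cnc2c1N` gives 320 nM in this assay, so that a 75-fold higher number from compound 1 to compound 3 (1.88 log units; beyond the scatter). Compound 2 `COC(=O)c1sc2cc(C#Cc3ccccc3OC)cnc2c1N` gives > 47300 nM in this assay, which is a limit of the assay rather than a number (the limit of > 47300 nM in this assay, at which 1 of the 3 values shown sits). Compound 4 `COC(=O)c1sc2cc(C#Cc3ccccc3F)cnc2c1N` differs from compound 3 by 2-fluorophenyl in place of 4-fluorophenyl on a triple-bonded carbon. The step that bears on this change is an at least 140-fold higher number from compound 1 to compound 2 (2.16 log units; beyond the scatter), where the same move of a methoxy group brought a large rise; the comparison an at least 1.9-fold lower number from compound 2 to compound 3 (0.29 log units; that floor lies within the scatter) adds little. A rise of a 2.5-fold higher number from compound 3 to compound 4 (0.40 log units; beyond the scatter) is therefore expected, which would carry compound 4 past the limit of the assay. Compound 4 is estimated at 60000 nM, between 20000 nM and 200000 nM.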

Compound 4, concentration for 50% growth inhibition: > 150000 nM
Compound 4: no number, only a limit (the forecaster's own chance of this, stated with the estimate: 65%); middle value at least 2.5-fold (0.39 log units) from the limit.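

In this assay, 2-fluorophenyl in place of 4-fluorophenyl on the triple-bonded carbon gives an at least 6.2-fold higher number from compound 3 to compound 4 (0.79 log units; beyond the scatter), so the loss seen when methoxy made the same move also appears with fluoro, and neither pair shown goes against it. Set against 4-methoxyphenyl, the same group gives an at least 460-fold higher number from compound 1 to compound 4 (2.67 log units; beyond the scatter). Compound 4 has no number, only a limit of the assay: the limit of > 150000 nM in this assay, at which 1 of the 4 values shown sits.

The step from compound 2 to compound 4 cannot be read, as both values are limits. Also open, as far as these compounds go, is whether 4-aminophenyl or 4-hydroxyphenyl on the triple-bonded carbon would come closer to compound 1 than 4-fluorophenyl does.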